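The compounds below may be only part of what the source reports. "The series", "measured", "known", "first", "only" and "open" are said of these compounds alone.

Measured so far:
- Compound 1 `COC(=O)c1ccc(NC(=O)C2(C(=O)Nc3ccc(Nc4ncc5cc(C(=O)N(C)C)n(C6CCCC6)c5n4)cc3)CC2)cc1`: 77.1%
- Compound 2 `CN(C)C(=O)c1cc2cnc(Nc3ccc(NC(=O)C4(C(=O)Nc5ccccc5F)CC4)cc3)nc2n1C1CCCC1`: 79.1%

Not yet measured:
- Compound 3 `CN(C)C(=O)c1cc2cnc(Nc3ccc(NC(=O)C4(C(=O)Nc5ccc(Br)cc5)CC4)cc3)nc2n1C1CCCC1`

In a functional assay on A549 cells (Homo sapiens) for inhibition, read by CCK-8 assay, with a stated time of 72 h, tested at 1 uM (on this read-out lower numbers stand for less inhibition of growth and higher numbers for more inhibition of growth at the one concentration tested), compound 2 gives 79.1%, and compound 1, at 77.1%, lies within the scatter of it. Compound 3 carries 4-bromophenyl in place of 2-fluorophenyl on an amide-type nitrogen. Within the data shown here, one measured step bears on this change, since it exchanged the group at the same place: a number 2 percentage points higher from compound 1 to compound 2 (within the scatter). Among the measured compounds shown here, that single step is small, although no measured compound yet carries 4-bromophenyl, so the expectation rests on thin evidence. No change beyond the scatter is therefore expected in this assay. The estimated step is a number 2.1 percentage points lower from compound 2 to compound 3 (within the scatter). For compound 3 the expected value is 77%, with an estimated range from 65% to 87%.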

Compound 3, percent growth inhibition at one concentration: -6.6%
Beside the measured number, compound 3's estimate is 83.6 percentage points above it, outside the stated range (below it).
By their numbers in this assay, from the lowest: compound 3; then compounds 1 and 2 (each within the scatter of the next).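

In this assay, the aryl group on this amide-type nitrogen proves far from interchangeable: 4-bromophenyl in place of 2-fluorophenyl gives a number 85.7 percentage points lower from compound 2 to compound 3 (beyond the scatter), although the two groups match in every count of heavy atoms, rings, donors, acceptors and charge. Bromo in place of methoxycarbonyl on an aromatic carbon gives a number 83.7 percentage points lower from compound 1 to compound 3 (beyond the scatter), so a 4-substituted phenyl does not by itself go with the loss, and compound 1 stands against any such pattern. No available evidence accounts for this collapse.

The exchange from compound 2 to compound 3 alters both the halogen and its place on the ring, and the compounds shown do not separate these two changes. On these data alone, whether 2-bromophenyl or 4-fluorophenyl would follow compound 2 or compound 3 remains open.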